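Spiro-oxindole triazole series: swapping the aryl on the triazole

The compounds below may be only part of what the source reports. "The series", "measured", "known", "first", "only" and "open" are said of these compounds alone.

Among the measured compounds shown here, compound 3 `N#CC1=C(N)Oc2c(N)cc3nc4ccccc4nc3c2C12C(=O)N(Cc1cnnn1-c1cc(Cl)ccc1Cl)c1ccccc12` is the one member of this set with a numerical value: in a functional assay on HepG2 cells (Homo sapiens) for antiproliferative activity, read by MTT assay, with a stated time of 48 h (on this read-out higher numbers stand for weaker inhibition and lower numbers for stronger inhibition), compound 3 gives 33100 nM. Compound 1 `N#CC1=C(N)Oc2c(N)cc3nc4ccccc4nc3c2C12C(=O)N(Cc1cnnn1-c1ccc([N+](=O)[O-])cc1)c1ccccc12` sits at a limit of the assay, > 50000 nM. Compound 2 `CCc1cccc(C)c1-n1nncc1CN1C(=O)C2(C(C#N)=C(N)Oc3c(N)cc4nc5ccccc5nc4c32)c2ccccc21` likewise reaches only a limit, > 50000 nM. The measured steps are therefore floors: an at least 1.5-fold lower number from compound 1 to compound 3 (0.17 log units; that floor lies within the scatter) and an at least 1.5-fold lower number from compound 2 to compound 3 (0.17 log units; that floor lies within the scatter), while a step that the two limits leave unreadable from compound 1 to compound 2. Compound 4 `N#CC1=C(N)Oc2c(N)cc3nc4ccccc4nc3c2C12C(=O)N(Cc1cnnn1-c1c(Cl)cc(Cl)cc1Cl)c1ccccc12` carries 2,4,6-trichlorophenyl in place of 2,5-dichlorophenyl on an aromatic nitrogen. Both earlier aryl swaps onto this nitrogen gave only floors within the scatter, so compound 4 is expected to stay near compound 3, with an estimated 1.1-fold higher number from compound 3 to compound 4 (0.02 log units; within the scatter). The estimate for compound 4 is 35000 nM, ranging from 12000 nM to 100000 nM.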

Compound 4, half-maximal inhibitory concentration: 37800 nM
The estimate for compound 4 lay 1.1-fold (0.03 log units) below the measured number, within the range that was stated.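

Among the compounds shown here, with a second number on this aromatic nitrogen, a step can for the first time be read in full in this assay: a 1.1-fold higher number from compound 3 to compound 4 (0.06 log units; within the scatter), so 2,5-dichlorophenyl and 2,4,6-trichlorophenyl cannot be told apart here. Against the other two aryl groups there are only floors, an at least 1.3-fold lower number from compound 2 to compound 4 (0.12 log units; that floor lies within the scatter) and an at least 1.3-fold lower number from compound 1 to compound 4 (0.12 log units; that floor lies within the scatter), and they can say no more because those two values are limits: the limit of > 50000 nM in this assay, at which 2 of the 4 values shown sit.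

Still open, going by these compounds, is whether an aryl group carrying an amine or a carboxylic acid, or a plain alkyl chain in place of the aryl, would give a clearly lower number at this nitrogen.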